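Indole-benzimidazole amides on lung cancer cells: adding methoxy groups

The compounds below may be only part of what the source reports. "The series", "measured", "known", "first", "only" and "open" are said of these compounds alone.

The series is built on one shared core, varied only in the aryl group attached to the carbonyl. Compound 1 `COc1ccc2c(c1)c(-c1nc3ccccc3n1C(=O)c1ccccc1)cn2C` carries a plain benzoyl group. In a functional assay on A549 cells (Homo sapiens) for inhibition, read by MTT assay, with a stated time of 24 h (on this read-out lower numbers stand for stronger inhibition of growth and higher numbers for weaker inhibition of growth), compound 1 gives 16700 nM. Compound 2 `COc1ccc2c(c1)c(-c1nc3ccccc3n1C(=O)c1ccccc1OC)cn2C` differs from it by methoxy in place of hydrogen on an aromatic carbon, and in this assay compound 2 gives 11900 nM; the step of a 1.4-fold lower number from compound 1 to compound 2 (0.15 log units; within the scatter) stays within the scatter. Compound 3 `COc1ccc2c(c1)c(-c1nc3ccccc3n1C(=O)c1ccc(OC)c(OC)c1)cn2C` differs from compound 1 by 3,4-dimethoxyphenyl in place of phenyl on a carbonyl carbon, and in this assay compound 3 gives 2700 nM. The steps of a 6.2-fold lower number from compound 1 to compound 3 (0.79 log units; beyond the scatter) and a 4.4-fold lower number from compound 2 to compound 3 (0.64 log units; beyond the scatter) are both beyond the scatter, so among these three compound 3 gives the lowest number.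

Compound 4 `COc1ccc2c(c1)c(-c1nc3ccccc3n1C(=O)c1cc(OC)c(OC)c(OC)c1)cn2C` is not yet measured. It differs from compound 3 by methoxy in place of hydrogen on an aromatic carbon. This is the same kind of change as that from compound 1 to compound 2, but not the same: there the entering methoxy sat ortho to a large group, here it sits ortho to a methoxy group and meta to a methoxy group as well as meta to a large group. Within the data shown here, the only measured guide is the step from compound 1 to compound 2, which was within the scatter. On that basis the step from compound 3 to compound 4 is expected to be small, estimated as a 1.4-fold lower number from compound 3 to compound 4 (0.13 log units; within the scatter). Compound 4 is therefore expected to give about 2000 nM in this assay, with a range from 700 nM to 6000 nM.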

Compound 4, concentration for 50% growth inhibition: 2400 nM
For compound 4 the middle estimate is 1.2-fold (0.08 log units) below the measured one, and the stated range covers the measured number.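

In this assay the new step is a 1.1-fold lower number from compound 3 to compound 4 (0.05 log units; within the scatter), so methoxy in place of hydrogen on an aromatic carbon gives the same reading on the core of compound 3 as on the core of compound 1, as far as these two pairs can tell: the same change on two cores in this assay, a 1.4-fold lower number (0.15 log units; within the scatter) from compound 1 to compound 2 and a 1.1-fold lower number (0.05 log units; within the scatter) from compound 3 to compound 4, 1.2-fold (0.10 log units) apart, within the scatter of two such steps. The change therefore carries across the two cases as one with no readable effect on the number, and neither case shows a gain from it. This does not show that methoxy is without effect wherever it is placed, as the entering group has different surroundings in the two pairs, and two pairs in a single cell assay are too few to make a rule for the series.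

The compounds shown leave open how an amine, a carboxylic acid or fluorine on the aryl group attached to the carbonyl would read, and whether a longer chain such as ethoxy in place of methoxy would change the number. They also leave open whether the same result would hold with any change to the shared core itself, which is identical in all four compounds.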